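Trading a carbamoyl arm for 3,5-difluorophenyl

The source may hold more compounds than are shown below. What is called first, only, known or untested is meant among the compounds shown, and "the series" means these compounds.

Among the measured compounds shown here, in an ADME assay on MT4 cells (Homo sapiens) for cytotoxicity, read by MTT assay (a lower number here means that less compound is tolerated, a higher number that more compound is tolerated), compound 2 (`Cc1cc(C)cc(S(=O)(=O)c2c(C(=O)NC(C)C(=O)NC(C)c3ccccc3F)[nH]c3ccc(Cl)cc23)c1`) gives 15200 nM and so holds the only true number so far. Compound 1 (`Cc1cc(C)cc(S(=O)(=O)c2c(C(=O)NCc3n[nH]c4ccccc34)[nH]c3ccc(Cl)cc23)c1`) reads > 50700 nM in this assay and that figure is a limit of the assay, not a number. Compound 2 therefore gives a firm starting point, but no ladder of values surrounds it.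

Compound 3 (`Cc1cc(C)cc(S(=O)(=O)c2c(C(=O)NC(C)c3cc(F)cc(F)c3)[nH]c3ccc(Cl)cc23)c1`) differs from compound 2 at one place (3,5-difluorophenyl in place of (1-(2-fluorophenyl)ethyl)carbamoyl on a saturated chain carbon bound to an amide-type nitrogen and a saturated chain carbon). In words, it carries 3,5-difluorophenyl in place of (1-(2-fluorophenyl)ethyl)carbamoyl on a saturated chain carbon bound to an amide-type nitrogen and a saturated chain carbon.

For the measured compounds named here, no measured pair of close relatives shows what a change like this does in this assay, so the forecast is necessarily loose. The expected change is slight, tilted towards more compound being tolerated and no larger than the usual scatter, with an estimated move (a 1.2-fold higher number from compound 2 to compound 3 (0.07 log units; within the scatter)). For compound 3 the estimated value is 18000 nM as the middle of the forecast. The expected range for compound 3 runs from 6000 nM up to 50000 nM in this wide first guess.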

Compound 3, half-maximal cytotoxic concentration: > 49700 nM
Compound 3 ended at the assay's limit; the forecaster's own chance of this, stated with the estimate: 25%; middle value at least 2.7-fold (0.44 log units) away from the limit.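

In this assay the swap of (1-(2-fluorophenyl)ethyl)carbamoyl for 3,5-difluorophenyl on this saturated chain carbon produces a clear move (an at least 3.2-fold higher number from compound 2 to compound 3 (0.51 log units; beyond the scatter)), so this position does respond to a change of group, in the direction of more compound being tolerated. The step between compound 1 and compound 3 cannot be read, as the two values are both limits, and compound 2 therefore remains the only one of the three with a true number. The reading of compound 3 is itself a limit of the assay and not a number: the limit of > 49700 nM in this assay, at which 1 of the 3 values shown sits.

As far as these compounds go, how far the true value of compound 3 lies beyond that limit stays open, and with it the full size of the step. The swap also removes the carbamoyl arm and brings in the 3,5-difluorophenyl in a single move, so the compounds shown cannot separate the two, and a plain phenyl or a primary amine on the same carbon would be needed to tell which part of the swap carries the shift.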